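From methoxy to trifluoromethoxy on compound 3

The source may report more compounds than this note shows. Statements on the series, on what has been measured and on what is new or still open speak of the compounds shown alone.

Of the compounds shown here, three sharing one core have been measured in an ADME assay on WI-38 cells (Homo sapiens) for cytotoxicity, read by MTT assay, with a stated time of 72 h; on this read-out lower numbers stand for stronger inhibition and higher numbers for weaker inhibition. Compound 1 `O=C(CCc1cccc2c1B(O)OC2)Nc1cccc(-c2ccccc2)c1` gives 12000 nM, and compound 2 `O=C(CCc1cccc2c1B(O)OC2)Nc1cccc(-c2ccc(Cl)cc2)c1` gives 9800 nM. Chloro in place of hydrogen on an aromatic carbon therefore amounts to a 1.2-fold lower number from compound 1 to compound 2 (0.09 log units; within the scatter). Compound 3 `COc1ccc(-c2cccc(NC(=O)CCc3cccc4c3B(O)OC4)c2)cc1` gives 1400 nM, the lowest number of the three. Methoxy in place of hydrogen amounts to an 8.6-fold lower number from compound 1 to compound 3 (0.93 log units; beyond the scatter), and methoxy in place of chloro amounts to a 7.0-fold lower number from compound 2 to compound 3 (0.85 log units; beyond the scatter).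

Compound 4 `O=C(CCc1cccc2c1B(O)OC2)Nc1cccc(-c2ccc(OC(F)(F)F)cc2)c1` has not yet been measured. It carries trifluoromethyl in place of methyl on an oxygen on an aromatic ring, so that methoxy becomes trifluoromethoxy. Among the compounds with values here, no measured step makes this exact change, and the three compounds offer only indirect guidance. The two steps that reach compound 3, an 8.6-fold lower number from compound 1 to compound 3 (0.93 log units; beyond the scatter) and a 7.0-fold lower number from compound 2 to compound 3 (0.85 log units; beyond the scatter), are the only ones beyond the scatter, and both involve removing or replacing the methoxy. If trifluoromethoxy fails to match methoxy, part of that separation should be lost, so a move to a higher number is expected, probably smaller than those two steps. The expected change is a 3.2-fold higher number from compound 3 to compound 4 (0.51 log units; beyond the scatter). Compound 4 is estimated at 4500 nM, with an expected range of 1500 nM to 12000 nM.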

Compound 4, half-maximal inhibitory concentration: 25000 nM
Estimate against measurement, compound 4: 5.6-fold (0.74 log units) below; measured number outside the range, above it.
By their numbers in this assay, from the lowest: compound 3; then compounds 2 and 1 (each within the scatter of the next); then compound 4.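

In this assay the exchange of methyl for trifluoromethyl on this oxygen gave an 18-fold higher number from compound 3 to compound 4 (1.25 log units; beyond the scatter) and so removed everything that set compound 3 apart: the methoxy result does not carry over to a closely related group on the same oxygen on an aromatic ring. Compound 4 also does not simply return to the level of the compounds without an oxygen at this place, since trifluoromethoxy in place of chloro gave a 2.6-fold higher number from compound 2 to compound 4 (0.41 log units; beyond the scatter) while trifluoromethoxy in place of hydrogen gave a 2.1-fold higher number from compound 1 to compound 4 (0.32 log units; beyond the scatter) and left compound 4 with the highest number of the four. No evidence at hand bears on why two groups on the same oxygen differ so widely.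

The compounds shown leave open whether a hydroxy group, an ethoxy chain or an amine in place of the methoxy would stay near compound 3 or move toward compound 4. They also leave open whether the exchange of methyl for trifluoromethyl would give a step of this size on a core other than the one shared here.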